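Swapping phenyl for tert-butyl in a well-tolerated compound

The source may hold more compounds than are shown below. What is called first, only, known or untested is meant among the compounds shown, and "the series" means these compounds.

Compound 1 `COc1ccc2[nH]c(C(=O)N3CC(=O)N(Cc4ccccc4)[C@@H](COc4ccccc4)C3)cc2c1` is the starting point. In an ADME assay on Vero cells (Chlorocebus sabaeus) for cytotoxicity, with a stated time of 7 days (a higher number here means that more compound is tolerated, a lower number that less compound is tolerated), compound 1 gives > 10000 nM as its result, and this is a limit of the assay, not a number. Compound 2 `COc1cccc(CN2C(=O)CN(C(=O)c3cc4cc(OC)ccc4[nH]3)C[C@@H]2CCc2ccccc2)c1` gives 4500 nM as a true number, so less of compound 2 is tolerated than of compound 1.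

Compound 3 `COc1ccc2[nH]c(C(=O)N3CC(=O)N(Cc4ccccc4)[C@@H](COC(C)(C)C)C3)cc2c1` keeps the core of compound 1 and changes one group, with tert-butyl in place of phenyl on an oxygen on a saturated carbon. Phenoxy thus becomes tert-butoxy. Within the data shown here, no measured pair here shows what such a swap does, so the closest guide is compound 1 with its limit of > 10000 nM in the same test. The step expected in this assay is none beyond the scatter, with no firm direction. In numbers, the estimated change is a number no higher from compound 1 to compound 3 (the limit leaves the size open) and is expected to be small. Compound 3 may well return only a limit too. The estimated value for compound 3 is 10000 nM (expected range 4000 nM to 20000 nM).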

Compound 3, half-maximal cytotoxic concentration: 78200 nM
Compound 3: the middle estimate sits 7.8-fold (0.89 log units) below what was measured, and the stated range ends below it.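

In this assay compound 1 gives > 10000 nM, which is a limit of the assay and not a number. No step from compound 1 to compound 3 can therefore be read, because one end of the comparison is only a limit: the limit of > 10000 nM in this assay, at which 1 of the 3 values shown sits.

The compounds shown leave open how large the swap from phenyl to tert-butyl is, and in which direction it goes.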